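Replacing a benzyl with a chlorophenoxyacetyl on the piperazine nitrogen

A few compounds are considered here, and "the series" means these few. Any claim that something is new, unique, unknown or untested is made for them only; others in the source may bear on it.

Measured compounds:
- compound 1 `COc1ccc(-c2cnc3nc(N)nc(N4CCN(C(=O)Nc5ccc(C)cc5)CC4)c3n2)cc1OC`: 0.8 nM
- compound 2 `COc1ccc(-c2cnc3nc(N)nc(N4CCN(Cc5ccc(C(C)(C)C)cc5)CC4)c3n2)cc1OC`: 4300 nM
- compound 3 `COc1ccc(-c2cnc3nc(N)nc(N4CCN(Cc5ccccc5)CC4)c3n2)cc1OC`: 900 nM

All three share one core and differ only in the group on an amine nitrogen in a ring. In a functional assay on cells (T-cell, Homo sapiens) for inhibition (on this read-out higher numbers stand for weaker inhibition and lower numbers for stronger inhibition), compound 1 gives 0.8 nM, compound 2 gives 4300 nM and compound 3 gives 900 nM. Compound 3 stands second highest of the three: a 4.8-fold lower number from compound 2 to compound 3 (0.68 log units; beyond the scatter), while a 1100-fold higher number from compound 1 to compound 3 (3.05 log units; beyond the scatter).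

Compound 4 `COc1ccc(-c2cnc3nc(N)nc(N4CCN(C(=O)COc5ccc(Cl)cc5)CC4)c3n2)cc1OC` carries ((4-chlorophenoxy)methyl)carbonyl in place of benzyl on an amine nitrogen in a ring. The step that bears most on it is a 1100-fold higher number from compound 1 to compound 3 (3.05 log units; beyond the scatter), where a benzyl replaced a carbamoyl group that, like the entering group, joins the ring nitrogen through a carbonyl. Going back from benzyl to a carbonyl-linked group may therefore recover part of that loss, though the entering group is not the carbamoyl of compound 1, so a full return is not expected. In this assay compound 4 is estimated at 40 nM (range 4 nM to 400 nM), an expected 23-fold lower number from compound 3 to compound 4 (1.35 log units; beyond the scatter).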

Compound 4, half-maximal inhibitory concentration: 0.5 nM
Compound 4: the middle estimate sits 80-fold (1.90 log units) above what was measured; the measured number lies below the stated range.
By their numbers in this assay, from the lowest: compounds 4 and 1 (each within the scatter of the next); then compound 3; then compound 2.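

In this assay putting ((4-chlorophenoxy)methyl)carbonyl on the amine nitrogen in a ring lowers the number sharply, whether it replaces benzyl (a 1800-fold lower number from compound 3 to compound 4 (3.26 log units; beyond the scatter)) or 4-(tert-butyl)benzyl (an 8600-fold lower number from compound 2 to compound 4 (3.93 log units; beyond the scatter)). The two compounds with a carbonyl on that nitrogen cannot be told apart (a 1.6-fold lower number from compound 1 to compound 4 (0.20 log units; within the scatter)), even though one carries (4-chlorophenoxy)methyl on the carbonyl carbon and the other (4-methylphenyl)amino. Across these four compounds, then, the low numbers go with a carbonyl on the ring nitrogen and the high numbers with a benzyl-type group, and no compound shown goes against this.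

No evidence is available to explain this split. As far as these compounds go, it remains open whether a small acetyl group, a sulfonyl group in place of the carbonyl, or a longer chain beyond the carbonyl would keep the number as low.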